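Bromine to nitrile on a fused benzo ring

This account rests on a few compounds, and the source may have more. Where it says the series, first, only, none or still open, it means among the compounds named here.

Compound 1 `CN1CCN(CCCN(C(=O)Nc2ccc(F)c(Cl)c2)C2CCc3ccccc3C2)CC1`: 380 nM
Compound 2 `CN1CCN(CCCN(C(=O)Nc2ccc(F)c(Cl)c2)C2CCc3cc(Br)ccc3C2)CC1`: 180 nM

Within the data shown here, in an assay on CHO cells for binding affinity to melanin-concentrating hormone receptor 1 (Homo sapiens) (on this read-out lower numbers stand for stronger inhibition and higher numbers for weaker inhibition), compound 2 gives the lower of the two numbers; the only measured step, a 2.1-fold lower number from compound 1 to compound 2 (0.32 log units; beyond the scatter), separates it from compound 1. Compound 3 `CN1CCN(CCCN(C(=O)Nc2ccc(F)c(Cl)c2)C2CCc3cc(C#N)ccc3C2)CC1` differs from compound 2 by cyano in place of bromo on an aromatic carbon. Among the measured compounds shown here, no measured step exchanges one group for another at this carbon, so the bromo step bears on compound 3 only in showing that substitution there is tolerated. A step within the usual scatter is therefore expected, and compound 3 is estimated at 250 nM (100 nM to 600 nM), an expected step of a 1.4-fold higher number from compound 2 to compound 3 (0.14 log units; within the scatter).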

Compound 3, inhibition constant: 340 nM
Estimate against measurement, compound 3: 1.4-fold (0.13 log units) below, and the stated range covers the measured number.
By their numbers in this assay, from the lowest: compounds 2, 3 and 1 (each within the scatter of the next, the first and the last beyond it).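

In this assay cyano in place of bromo on this aromatic carbon gives a 1.9-fold higher number from compound 2 to compound 3 (0.28 log units; within the scatter) and cyano in place of hydrogen gives a 1.1-fold lower number from compound 1 to compound 3 (0.05 log units; within the scatter) with both steps within the scatter. The carbon therefore carries a cyano group as well as a bromo group, but compound 3 cannot be told apart from either compound 1 or compound 2, so cyano does not clearly share the step seen from hydrogen to bromo. No available evidence explains these steps. Going by these compounds, whether an amine, a methoxy group or a carboxylic acid on this carbon would give a step beyond the scatter remains open.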